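A Smaller Aryl Group on the Carbonyl Carbon

This account rests on a few compounds, and the source may have more. Where it says the series, first, only, none or still open, it means among the compounds named here.

Among the compounds with values here, compound 3 `O=C(Nc1c(C(O)(C(F)(F)F)C(F)(F)F)ccc2ccccc12)c1cccc(Cl)c1Cl` stands at the top of the numbers so far. In an assay on LtK cells with ATP-sensitive inward rectifier potassium channel 11 (Homo sapiens) as the target (on this read-out lower numbers stand for an effect already at smaller amounts and higher numbers for an effect only at larger amounts of compound), compound 3 gives only a limit, > 10000 nM. Compound 1 `CC(=O)Nc1c(C(O)(C(F)(F)F)C(F)(F)F)ccc2ccccc12`, which carries a methyl on the carbonyl carbon, gives 18 nM in this assay, and compound 2 `CCC(CC)C(=O)Nc1c(C(O)(C(F)(F)F)C(F)(F)F)ccc2ccccc12` gives 4340 nM there. The steps already measured all lead upward from compound 1: a 240-fold higher number from compound 1 to compound 2 (2.38 log units; beyond the scatter) and an at least 550-fold higher number from compound 1 to compound 3 (2.74 log units; beyond the scatter), while between the two larger groups an at least 2.3-fold higher number from compound 2 to compound 3 (0.36 log units; beyond the scatter).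

Compound 4 `O=C(Nc1c(C(O)(C(F)(F)F)C(F)(F)F)ccc2ccccc12)c1ccco1` differs from compound 3 in one place: furan-2-yl in place of 2,3-dichlorophenyl on a carbonyl carbon. Among the three measured compounds the larger groups on the carbonyl carbon go with the higher numbers, and compound 3 sits at the limit (the limit of > 10000 nM in this assay, at which 1 of the 3 values shown sits); a smaller aromatic group is therefore expected to bring the number down in this assay, though not to the level seen for compound 1 with its methyl. Compound 4 is expected to give 3000 nM in this assay, within a range of 500 nM to 20000 nM. This would correspond to an expected step of an at least 3.3-fold lower number from compound 3 to compound 4 (0.52 log units; beyond the scatter).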

Compound 4, half-maximal effective concentration: 9 nM
For compound 4 the middle estimate is 330-fold (2.52 log units) above the measured one; measured number below the stated range.
By their numbers in this assay, from the lowest: compounds 4 and 1 (each within the scatter of the next); then compound 2. At a limit, above all of these: compound 3.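

At this position, the carbonyl carbon, an aromatic ring is compatible with a low number in this assay: furan-2-yl and methyl cannot be told apart, with a 2.0-fold lower number from compound 1 to compound 4 (0.30 log units; within the scatter). Among the earlier compounds larger groups went with higher numbers, but compound 4 goes against that pattern, since furan-2-yl stands far from pentan-3-yl, with a 480-fold lower number from compound 2 to compound 4 (2.68 log units; beyond the scatter), and from 2,3-dichlorophenyl, with an at least 1100-fold lower number from compound 3 to compound 4 (3.04 log units; beyond the scatter). Compound 3 gives only a limit, so the last of these steps is a lower bound on the true difference: the limit of > 10000 nM in this assay, at which 1 of the 4 values shown sits.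

The compounds shown leave open whether the gap between the two aromatic groups follows the ring oxygen of furan-2-yl, the five-membered ring or the absence of the two chlorine atoms, and a plain phenyl or a thiophen-2-yl on the carbonyl carbon would help to separate these. Also open, from the compounds shown here alone, is how a straight propyl chain, which would fall in size between methyl and pentan-3-yl, or a group carrying an amine would behave at this position.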